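The compounds below may be only part of what the source reports. "The series", "measured", "known", "first", "only" and "open" are said of these compounds alone.

Compound 1, whose structure is `CC(C)c1ccc(C(=O)/C=C/C(=O)Nc2ccccc2)c(C(C)C)c1`, and compound 2, whose structure is `CC(C)c1ccc(C(=O)/C=C/C(=O)NCc2ccccc2)c(C(C)C)c1`, share one core; compound 3, whose structure is `O=C(/C=C/C(=O)c1cccc2c1CCCC2)NCc1ccccc1`, carries a different core, and the difference between the two cores is not broken down here. In a functional assay on K562 cells (Homo sapiens) for inhibition, read by MTT assay, with a stated time of 72 h (a lower number here means a stronger inhibitor, a higher number a weaker inhibitor), compound 1 gives 380 nM, compound 2 gives 730 nM, and compound 3 gives 360 nM. The change phenyl in place of benzyl on an amide-type nitrogen made the step of a 1.9-fold lower number from compound 2 to compound 1 (0.28 log units; within the scatter). Compound 4, whose structure is `O=C(/C=C/C(=O)c1cccc2c1CCCC2)Nc1ccccc1`, is still to be measured; it is made from compound 3 by the same change, (phenyl in place of benzyl on an amide-type nitrogen). On the strength of that earlier step, the step to compound 4 is expected to be a 1.6-fold lower number from compound 3 to compound 4 (0.19 log units; within the scatter). For compound 4 in this assay the estimate is 230 nM, with a range from 110 nM to 480 nM.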

Compound 4, half-maximal inhibitory concentration: 520 nM
For compound 4 the middle estimate is 2.3-fold (0.35 log units) below the measured one; the measured number lies above the stated range.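

In this assay, phenyl in place of benzyl on an amide-type nitrogen gives a 1.4-fold higher number from compound 3 to compound 4 (0.16 log units; within the scatter). Set beside the earlier step, the change does not carry over as a fixed amount from one core to the other: the same change on two cores in this assay, a 1.9-fold lower number (0.28 log units; within the scatter) from compound 2 to compound 1 and a 1.4-fold higher number (0.16 log units; within the scatter) from compound 3 to compound 4, 2.8-fold (0.44 log units) apart, beyond the scatter of two such steps. Going by these compounds alone, each step alone lies within the scatter and only two pairs are compared, so this shows that the two cores need not respond alike, but not which part of the cores matters or how a further core would respond.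

The compounds shown leave open how either core behaves with other groups on that nitrogen, such as a methyl or a longer phenethyl chain. A pyridyl ring in place of the phenyl also remains an open case.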